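Swapping the dichlorophenyl for isopropylphenyl in compound 4

The source may hold more compounds than are shown below. What is called first, only, known or untested is meant among the compounds shown, and "the series" means these compounds.

Compound 1, `CC(C)(C)Cc1c(-c2ccncc2)sc(N)c1C(=O)c1ccc(Cl)cc1`, gives 6% in an assay on CHO cells for displacement of a labelled ligand from adenosine receptor A3 (Homo sapiens), read by scintillation counting, tested at 10 uM; on this read-out lower numbers stand for less inhibition and higher numbers for more inhibition at the one concentration tested (going by the name of the read-out).
Compound 2, `CC(C)(C)Cc1c(-c2ccc(Cl)cc2)sc(N)c1C(=O)c1ccc(Cl)cc1`, gives 1% in this assay.
Compound 3, `CC(C)(C)Cc1c(-c2ccc(Cl)c(Cl)c2)sc(N)c1C(=O)c1ccc(Cl)cc1`, gives 1% in this assay.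

Compound 3 sits level with compound 2 at the digits shown, and the two together are the lowest of the three numbers; the step of no change at the digits printed from compound 2 to compound 3 (within the scatter) stays within the scatter, as does a number 5 percentage points lower from compound 1 to compound 3 (within the scatter). All three measured compounds lie in a narrow band near the bottom of the read-out.

The unmeasured compound 4, `CC(C)c1ccc(-c2sc(N)c(C(=O)c3ccc(Cl)cc3)c2CC(C)(C)C)cc1`, differs from compound 3 in one place: 4-isopropylphenyl in place of 3,4-dichlorophenyl on an aromatic carbon. Within the data shown here, the steps that bear on this change are the aryl swaps a number 5 percentage points lower from compound 1 to compound 2 (within the scatter) and a number 5 percentage points lower from compound 1 to compound 3 (within the scatter), together with no change at the digits printed from compound 2 to compound 3 (within the scatter); none of them leaves the scatter. Another change of the same aryl group is therefore expected to give no step beyond the scatter, an expected a number 1 percentage points higher from compound 3 to compound 4 (within the scatter) in this assay. Compound 4 is estimated at 2%, within 0% to 12%.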

Compound 4, a percentage reported as inhibition, at one concentration (the size of the read-out at that concentration, not a potency): 1%
For compound 4 the middle estimate is 1 percentage points above the measured one; the measured number falls inside the stated range.
By their numbers in this assay, from the lowest: compounds 2, 3, 4 and 1 (each within the scatter of the next).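

In this assay the aromatic carbon next to the ring sulfur also accepts 4-isopropylphenyl, a group of carbon only, in place of 3,4-dichlorophenyl, and the step is no change at the digits printed from compound 3 to compound 4 (within the scatter). Isopropyl in place of chloro on the same phenyl ring gives no change at the digits printed from compound 2 to compound 4 (within the scatter), while 4-isopropylphenyl in place of pyridin-4-yl gives a number 5 percentage points lower from compound 1 to compound 4 (within the scatter). An alkyl substituent on this phenyl ring thus joins the chloro, dichloro and pyridine variants in the same narrow band near the bottom of the read-out, with no aryl group here separated from another beyond the scatter.

No evidence is available to explain these numbers. On these data alone, it remains open whether an amine or a carboxylic acid on this phenyl ring, or a longer chain in place of the neopentyl group, would move the number out of this band.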